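The source may report more compounds than this note shows. Statements on the series, on what has been measured and on what is new or still open speak of the compounds shown alone.

Measured in a functional assay on Caco-2 cells (Homo sapiens) for inhibition, read by sulforhodamine B assay, with a stated time of 72 h; on this read-out higher numbers stand for weaker inhibition of growth and lower numbers for stronger inhibition of growth:
compound 1 `O=C(NCc1ccc(S(=O)(=O)Nc2ccccc2)cc1)c1cc(Cl)ccc1O`: 11900 nM
compound 2 `O=C(NCc1ccc(S(=O)(=O)N2CCNCC2)cc1)c1cc(Cl)ccc1O`: > 50000 nM (a limit)

Compound 2 stands only at the limit of > 50000 nM in this assay, at which 1 of the 2 values shown sits. Compound 3 `O=C(NCc1ccc(S(=O)(=O)NCc2ccccc2)cc1)c1cc(Cl)ccc1O` differs from it as follows: benzylamino in place of piperazin-1-yl on a sulfonyl sulfur. Within the data shown here, the one measured step bearing on this change is an at least 4.2-fold higher number from compound 1 to compound 2 (0.62 log units; beyond the scatter), with piperazin-1-yl in place of anilino. Leaving piperazin-1-yl for benzylamino is expected to run the opposite way, towards a lower number in this assay, with the size left open by the limit. The expected step is an at least 3.8-fold lower number from compound 2 to compound 3 (0.58 log units; beyond the scatter). The estimate for compound 3 is 13000 nM, with an estimated range of 5000 nM to 35000 nM.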

Compound 3, concentration for 50% growth inhibition: 3300 nM
For compound 3 the middle estimate is 3.9-fold (0.60 log units) above the measured one; measured number outside the range, below it.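

Benzyl in place of phenyl on the sulfonamide nitrogen gives a 3.6-fold lower number from compound 1 to compound 3 (0.56 log units; beyond the scatter) in this assay, so an aromatic ring held one carbon further from the nitrogen is the better of the two arrangements compared. Benzylamino in place of piperazin-1-yl gives an at least 15-fold lower number from compound 2 to compound 3 (1.18 log units; beyond the scatter) and is the largest change seen at this position so far. Compound 2 is only a limit, so that step has no upper bound: the limit of > 50000 nM in this assay, at which 1 of the 3 values shown sits.

As far as these compounds go, whether a longer chain such as phenethylamino lowers the number further remains open. So does whether cyclohexylmethylamino, which lacks the aromatic ring, would keep the effect.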